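A few compounds are considered here, and "the series" means these few. Any claim that something is new, unique, unknown or untested is made for them only; others in the source may bear on it.

Notes on the series. Compound 1 `CNC(=O)c1cc(Oc2ccc3nc(Nc4ccccc4)ncc3c2)ccn1` is the reference point. In a physicochemical assay for solubility, at pH 7 (on this read-out lower numbers stand for lower solubility and higher numbers for higher solubility), compound 1 gives < 1000 nM, which is a limit of the assay and not a number. Compound 2 `CNC(=O)c1cc(Oc2ccc3nc(Nc4cccc(C(C)(C)C)c4)cnc3c2)ccn1` belongs to the same set. In this assay compound 2 gives < 1000 nM, again a limit rather than a measured number. Where compound 1 stands is therefore known only as a limit, and so is the other value shown, since (the limit of < 1000 nM in this assay, at which 2 of the 2 values shown sit). Within the data shown here, no step between measured compounds is available: no two of them differ in one place.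

Compound 3 `CNC(=O)c1cc(Oc2ccc3nc(Nc4ccccc4Br)ncc3c2)ccn1` has not yet been measured. Its difference from compound 1 is bromo in place of hydrogen on an aromatic carbon, ortho to a large group, read one bond further out as anilino to (2-bromophenyl)amino. Among the measured compounds shown here, with no measured step to lean on and both known values sitting at the limit, the expected step is a step that the limit leaves unreadable from compound 1 to compound 3, keeping the value at that same limit rather than moving it away. For compound 3 the estimate is 400 nM, in the range 100 nM to 1000 nM.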

Compound 3, solubility: < 1000 nM
Compound 3: no number, only a limit; the forecaster's own chance of this, stated with the estimate: 80%; the middle value is on the limit's open side.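

No step can be read between compound 1 and compound 3 in this assay, since each gives only a limit and not a number: the limit of < 1000 nM in this assay, at which 3 of the 3 values shown sit.

The compounds shown leave open where compound 1, compound 2 and compound 3 stand relative to one another, and whether bromo in place of hydrogen on an aromatic carbon moves the value at all.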